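Swapping a Thiophene Ring for a Pyridine Ring

A few compounds are considered here, and "the series" means these few. Any claim that something is new, unique, unknown or untested is made for them only; others in the source may bear on it.

Three compounds share one core, and the cytotoxicity of one of them was measured in an ADME assay on HEK293 cells (Homo sapiens) for cytotoxicity, read by CCK-8 assay and cell counting, with a stated time of 2 days; on this read-out higher numbers stand for weaker inhibition and lower numbers for stronger inhibition. Compound 1 `Oc1ccc(-c2cc(-c3cccnc3)nc(-c3ccccc3Cl)c2)cc1` has the entry "not determined" (no result reported) in this assay, and compound 2 `Oc1ccc(-c2cc(-c3ccncc3)nc(-c3ccc(Cl)cc3)c2)cc1` likewise has the entry "not determined" (no result reported) in this assay. Among the measured compounds shown here, compound 3 `Oc1ccc(-c2cc(-c3ccc(Cl)cc3)nc(-c3cccs3)c2)cc1` is therefore the only compound with a number here; in this assay compound 3 gives 4520 nM, which is the sole point of reference. Compound 4 `Oc1ccc(-c2cc(-c3ccc(Cl)cc3)nc(-c3cccnc3)c2)cc1` differs from compound 3 in one place: pyridin-3-yl in place of thiophen-2-yl on an aromatic carbon. For the measured compounds named here, no measured step of this kind is available, so the direction can only be guessed. A modest move toward weaker inhibition, or no change beyond the usual scatter, is expected, with the step of a 1.3-fold higher number from compound 3 to compound 4 (0.12 log units; within the scatter) as the estimate. Compound 4 is expected to give about 6000 nM, with a likely range from 2500 nM to 15000 nM.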

Compound 4, half-maximal inhibitory concentration: 27500 nM
Estimate against measurement, compound 4: 4.6-fold (0.66 log units) below; the measured number lies above the stated range.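

In this assay, pyridin-3-yl in place of thiophen-2-yl gives a 6.1-fold higher number from compound 3 to compound 4 (0.78 log units; beyond the scatter), a move toward weaker inhibition. This shows that the number responds to which aromatic ring sits on this carbon next to the ring nitrogen, even though both groups count the same hydrogen-bond acceptors and carry no net charge. Nothing shown here explains the rise.

On these data alone, this is a single step at one position, so any wider trend remains unknown. As far as these compounds go, it also remains open how an open-chain group, such as an amine or a carboxylic acid, would read on this carbon.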